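The compounds below may be only part of what the source reports. "The series", "measured", "known", "first", "only" and "open" are said of these compounds alone.

Compound 1 `Clc1ccc2[nH]c(-c3cn(-c4ccccc4)nc3-c3ccccc3)nc2c1`: > 50000 nM
Compound 2 `Fc1ccc(-c2nn(-c3ccccc3)cc2-c2nc3ccccc3[nH]2)cc1`: > 50000 nM

In an ADME assay on HaCaT cells (Homo sapiens) for cytotoxicity, read by MTT assay, with a stated time of 48 h (on this read-out lower numbers stand for stronger inhibition and higher numbers for weaker inhibition), compound 2 stands at > 50000 nM, which is a limit of the assay and not a number. Compound 1 also gives only a limit. Compound 3 `Fc1ccc(-c2nn(-c3ccccc3)cc2-c2nc3cc(Br)ccc3[nH]2)cc1` differs from compound 2 by bromo in place of hydrogen on an aromatic carbon. Among the measured compounds shown here, no measured step gauges this change, and only a change within the scatter is expected in this assay because the limit of > 50000 nM in this assay, at which 2 of the 2 values shown sit, is all that the data show. The expected size of a number no higher from compound 2 to compound 3 (the limit leaves the size open) lies within the scatter. Compound 3 is estimated at 50000 nM, with an expected range of 25000 nM to 100000 nM.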

Compound 3, half-maximal inhibitory concentration: 21800 nM
For compound 3 the middle estimate is 2.3-fold (0.36 log units) above the measured one, outside the stated range (below it).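

In this assay, bromo in place of hydrogen on an aromatic carbon of the fused ring system gives an at least 2.2-fold lower number from compound 2 to compound 3 (0.36 log units; beyond the scatter). Compound 3 is the first compound shown with a real number rather than a limit, so substitution at this position can register in this read-out. The full size of the step stays open because compound 2 gives only a limit: the limit of > 50000 nM in this assay, at which 2 of the 3 values shown sit.

Going by these compounds, whether an amine, a methoxy group or a nitrile on this same carbon would also lower the number remains open. So does whether bromo would do the same on the core of compound 1.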